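The compounds below may be only part of what the source reports. "The series", "measured", "known", "first", "only" and "open" are said of these compounds alone.

Measured compounds:
- compound 1 `O=C(CN1CCC(c2cccc[n+]2[O-])CC1)Nc1ccc(F)cc1F` gives 74% in a functional assay on HEK293 cells for agonist activity at D(4) dopamine receptor (Homo sapiens), read by FLIPR; a higher number here means a larger maximal response, a lower number a smaller maximal response
- compound 2 `Cc1cccc(NC(=O)CN2CCC(c3cccc(F)c3)CC2)c1` gives 40% in this assay
- compound 3 `O=C(CN1CCC(c2cccc[n+]2[O-])CC1)Nc1ccc(F)cc1C(F)(F)F` gives 65% in this assay

Compound 1 stands highest of the three numbers, but its separation from compound 3 is within the scatter, so the two cannot be ordered; only compound 2, with its far lower value, is clearly separated from compound 1.

The unmeasured compound 4 `Cc1cc(Br)ccc1NC(=O)CN1CCC(c2cccc[n+]2[O-])CC1` differs from compound 1 in one place: 4-bromo-2-methylphenyl in place of 2,4-difluorophenyl on an amide-type nitrogen. Among the measured compounds shown here, the one step that bears on this is the change on the same aromatic ring from compound 1 to compound 3, a number 9 percentage points lower from compound 1 to compound 3 (within the scatter), which did not move the response beyond the scatter. Compound 2 carries a methyl on the amide-side ring, but its core also differs from that of compound 1, so its low value cannot be assigned to the ring substituent. For the measured compounds named here, with only one relevant step, and that one flat, no movement beyond the scatter is expected in this assay for compound 4; a modest downward drift, a number 12 percentage points lower from compound 1 to compound 4 (beyond the scatter), is the estimated step. Compound 4 is thus expected to give 62%, with a range from 42% to 80%.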

Compound 4, largest response reached (reported as efficacy), in percent of the reference or control that the assay uses: 61%
For compound 4 the middle estimate is 1 percentage points above the measured one; the range from low to high includes it.
By their numbers in this assay, from the lowest: compound 2; then compounds 4, 3 and 1 (each within the scatter of the next, the first and the last beyond it).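

Among the compounds shown here, at the amide-type nitrogen, 4-bromo-2-methylphenyl in place of 2,4-difluorophenyl gives a number 13 percentage points lower from compound 1 to compound 4 (beyond the scatter) in this assay, the first step on the shared core that lies beyond the scatter, though it is modest. The aryl group at this position can therefore shift the maximal response, while a substantial response remains with neither fluorine retained; compounds 3 and 4 are within the scatter of each other and cannot be ordered. No measurement is available that accounts for this step.

Bromo and methyl enter together in compound 4, so the separate contribution of each, and of removing each fluoro, remains open. Also open, from the compounds shown here alone, is how the response would read with a nitrile, a methoxy or a carboxylic acid on this ring, or with a cyclohexyl group in place of the aryl ring.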